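The compounds below may be only part of what the source reports. "The series", "measured", "known", "first", "only" and "open" are said of these compounds alone.

Working notes on the series. In a functional assay on MDA-MB-231 cells (Homo sapiens) for antiproliferative activity, read by sulforhodamine B assay, with a stated time of 48 h (a lower number here means a stronger inhibitor of growth, a higher number a weaker inhibitor of growth), compound 1 (`CCCCCc1ccc(-c2cn(CCCN3C(=O)COc4ccccc43)nn2)cc1`) gives 5000 nM and compound 2 (`O=C1COc2ccccc2N1CCCn1cc(-c2ccccn2)nn1`) gives 4800 nM. Among the measured compounds shown here, these two values lie within the usual scatter of each other, so compound 2 stands level with the only other measured compound and no order can be drawn.

Compound 3 (`CCCc1cn(CCCN2C(=O)COc3ccccc32)nn1`) has propyl in place of pyridin-2-yl on an aromatic carbon of the compound 2 structure: propyl in place of pyridin-2-yl on an aromatic carbon. No measured pair isolates a change of this kind, so what losing the ring of pyridin-2-yl does in this assay is not shown by the data.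

With compound 1 at 5000 nM and compound 2 at 4800 nM, the measured values give no sign of a wide spread, and a large shift is not expected. A small step toward weaker growth inhibition is the working expectation, and it may not exceed the scatter. The expected step is a 1.5-fold higher number from compound 2 to compound 3 (0.16 log units; within the scatter). For compound 3 the estimated value is 7000 nM, with an expected range of 3000 nM to 18000 nM.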

Compound 3, concentration for 50% growth inhibition: 1100 nM
The estimate for compound 3 lay 6.4-fold (0.80 log units) above the measured number, and the stated range ends above it.
By their numbers in this assay, from the lowest: compound 3; then compounds 2 and 1 (each within the scatter of the next).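

Among the compounds shown here, on the aromatic carbon of the five-membered aromatic ring with 3 nitrogen, propyl in place of pyridin-2-yl gives a 4.4-fold lower number from compound 2 to compound 3 (0.64 log units; beyond the scatter) in this assay, the first step to lie beyond the scatter. This position therefore responds to a change of group, and a ring on this carbon is not required for growth inhibition: compound 3, which has no ring there, gives 1100 nM and has the lowest number of the series. No measurement available here bears on why the number falls with this change.

The step removes the ring of pyridin-2-yl and brings in a propyl chain at once, so the contribution of each remains unseparated. Also open, going by these compounds, is how this carbon would respond to a shorter chain such as ethyl, a longer chain such as hexyl, or a propyl chain ending in an amine or a carboxylic acid, and whether the number would keep falling or rise again with any of these.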